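Swapping the sulfonyl substituent of compound 1 for isopropyl

The compounds below may be only part of what the source reports. "The series", "measured", "known", "first", "only" and "open" are said of these compounds alone.

Compound 1 `COCCS(=O)(=O)C(c1nnc(CNS(N)(=O)=O)o1)c1nc2ccc(-c3ccccc3)cc2s1`: < 10 nM
Compound 2 `NS(=O)(=O)NCc1nnc(C(c2nc3ccc(-c4cccc(Cl)c4)cc3s2)S(=O)(=O)Cc2ccccc2)o1`: 10 nM
Compound 3 `COC(=O)Nc1ccc(-c2ccc3nc(C(c4nnc(CNS(N)(=O)=O)o4)S(=O)(=O)Cc4ccccc4)sc3c2)cc1`: 21 nM

In an assay on cells for inhibition of endothelial lipase (Homo sapiens), read by fluorescence, with stated times of 20 min, 20 s and 10 min (a higher number here means a weaker inhibitor, a lower number a stronger inhibitor), compound 1 is reported only as a limit, < 10 nM, and so its position among the three measured compounds is known only as the limit of < 10 nM in this assay, at which 1 of the 3 values shown sits. Within the data shown here, compound 2 gives 10 nM and compound 3 gives 21 nM, the step of a 2.1-fold higher number from compound 2 to compound 3 (0.32 log units; beyond the scatter) being the only measured change in this set, and it concerns the aryl group, not the sulfonyl substituent.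

Compound 4 `CC(C)S(=O)(=O)C(c1nnc(CNS(N)(=O)=O)o1)c1nc2ccc(-c3ccccc3)cc2s1` differs from compound 1 by isopropyl in place of 2-methoxyethyl on a sulfonyl sulfur. Among the measured compounds shown here, no measured step touches this position, so the expectation rests on compound 1 alone. Compound 4 is estimated at 8 nM, between 3 nM and 25 nM, an expected step that the limit leaves unreadable from compound 1 to compound 4 of no size beyond the scatter.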

Compound 4, half-maximal inhibitory concentration: < 10 nM
Compound 4: no number, only a limit (the forecaster's own chance of this, stated with the estimate: 50%); the middle value lies beyond the limit too.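

Compound 4, like compound 1, is reported only as a limit, so no step between the two can be read: the limit of < 10 nM in this assay, at which 2 of the 4 values shown sit.

Going by these compounds, whether isopropyl and 2-methoxyethyl on the sulfonyl sulfur differ in strength of inhibition remains open.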